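A few compounds are considered here, and "the series" means these few. Any claim that something is new, unique, unknown or untested is made for them only; others in the source may bear on it.

Measured so far in a functional assay on SGC-7901 cells (Homo sapiens) for cytotoxicity, read by MTT assay, with a stated time of 48 h; a higher number here means a weaker inhibitor, a lower number a stronger inhibitor:
compound 1 `Cc1ncc([N+](=O)[O-])n1CCSc1nnc(-c2ccccc2F)o1` gives 33700 nM
compound 2 `COc1cc(OC)cc(-c2nnc(SCCn3c([N+](=O)[O-])cnc3C)o2)c1` gives 9600 nM
compound 3 `COc1cc(-c2nnc(SCCn3c([N+](=O)[O-])cnc3C)o2)cc(OC)c1OC` gives 34800 nM

Among these three numbers compound 1 stands second highest: it sits within the scatter of compound 3, and only compound 2, with the lowest number, lies beyond the scatter from it. Among the compounds with values here, the single step between measured compounds, a 3.6-fold higher number from compound 2 to compound 3 (0.56 log units; beyond the scatter), is a modest move for a methoxy in place of hydrogen on an aromatic carbon; it says nothing about exchanging the ring attached to the shared core. Compound 4 `Cc1ncc([N+](=O)[O-])n1CCSc1nnc(-c2ccnc(Cl)c2)o1` differs from compound 1 in exactly that way: 2-chloropyridin-4-yl in place of 2-fluorophenyl on an aromatic carbon. Within the data shown here, no measured pair shows a change of this kind, so there is no ground for expecting a move beyond the scatter in either direction. The expected step is a 1.1-fold lower number from compound 1 to compound 4 (0.05 log units; within the scatter), which keeps compound 4 close to compound 1. The estimate for compound 4 in this assay is 30000 nM, with a range from 10000 nM to 90000 nM.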

Compound 4, half-maximal inhibitory concentration: 32300 nM
Compound 4: the middle estimate sits 1.1-fold (0.03 log units) below what was measured, and the stated range covers the measured number.
By their numbers in this assay, from the lowest: compound 2; then compounds 4, 1 and 3 (each within the scatter of the next).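

In this assay, putting 2-chloropyridin-4-yl in place of 2-fluorophenyl on the aromatic carbon of the five-membered ring gives a 1.0-fold lower number from compound 1 to compound 4 (0.02 log units; within the scatter) and so leaves the read-out unchanged for practical purposes. This is the first exchange of the whole attached ring among these compounds, and it shows that a ring with 1 hetero atom and a chlorine can stand where a carbon-only ring with a fluorine stood, with no change beyond the scatter. No supporting information is available to explain this outcome.

A single exchange cannot show whether the ring nitrogen and the halogen swap each have no effect or instead offset each other, and an unsubstituted phenyl would help to separate them. As far as these compounds go, whether a non-aromatic group at this place, such as an amine, a carboxylic acid or a longer chain, would shift the number also remains open.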